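Ethyl in Place of Hydrogen on the Amide Methyl

A few compounds are considered here, and "the series" means these few. Any claim that something is new, unique, unknown or untested is made for them only; others in the source may bear on it.

In a functional assay on A549 cells (Homo sapiens) for cytotoxicity, read by XTT assay, with a stated time of 72 h (on this read-out lower numbers stand for stronger inhibition and higher numbers for weaker inhibition), the measured compounds stand as follows:
Compound 1 `O=C1C=CC(=O)C(c2cc(-c3ccc(C(=O)N4CCC(C(F)(F)F)CC4)s3)on2)=C1` gives > 30000 nM, a limit of the assay.
Compound 2 `COc1ccc(OC)c(-c2cc(-c3ccc(C(=O)N(C)C)s3)on2)c1` gives > 30000 nM, a limit of the assay.
Compound 3 `COc1ccc(CN(C)C(=O)c2ccc(-c3cc(-c4cc(OC)ccc4OC)no3)s2)cc1` gives > 30000 nM, a limit of the assay.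

Compound 2 thus stands at the limit, and so do the other two, as the limit of > 30000 nM in this assay, at which 3 of the 3 values shown sit, records. Among the compounds with values here, the one measured step that touches compound 2 is a step that the two limits leave unreadable from compound 2 to compound 3, and its size cannot be read. Compound 4 `CCCN(C)C(=O)c1ccc(-c2cc(-c3cc(OC)ccc3OC)no2)s1` differs from compound 2 by ethyl in place of hydrogen on a saturated chain carbon bound to an amide-type nitrogen. Within the data shown here, no measured step bears readably on this change, so no step beyond the scatter is expected in this assay, and a further limit is the most probable outcome. Compound 4 is estimated at 50000 nM, within 15000 nM to 200000 nM. That estimate means an expected step that the limit leaves unreadable from compound 2 to compound 4.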

Compound 4, half-maximal inhibitory concentration: > 30000 nM
Compound 4: a limit, no number; the forecaster's own chance of this, stated with the estimate: 85%; the middle value does not contradict the limit.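

Compound 4 gives > 30000 nM, a limit of the assay, and its steps to compound 2 and compound 3 cannot be read. The compounds shown leave open whether any amide substituent gives a measurable value in this assay.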